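From Ethyl Ester to Free Acid: An Expected Loss

The compounds below may be only part of what the source reports. "The series", "measured", "known", "first", "only" and "open" are said of these compounds alone.

Measured so far:
compound 1 `COc1ccc(-c2oc3c(CC=C(C)C)c(OCC(=O)O)cc(O)c3c(=O)c2OCC(=O)O)cc1`: > 100000 nM
compound 2 `COc1ccc(-c2oc3c(CC=C(C)C)c(OC(C(=O)O)C(=O)O)cc(O)c3c(=O)c2OC(C(=O)O)C(=O)O)cc1`: 78900 nM
compound 3 `CCOC(=O)COc1cc(O)c2c(=O)c(O)c(-c3ccc(OC)cc3)oc2c1CC=C(C)C`: 5300 nM

All three were tested in a functional assay on MDA-MB-435S cells (Homo sapiens) for cytotoxicity, read by MTT assay; on this read-out lower numbers stand for stronger inhibition and higher numbers for weaker inhibition. For compound 1 the result is a limit of the assay, not a number: the limit of > 100000 nM in this assay, at which 1 of the 3 values shown sits. Compound 2 carries two free acid groups and gives 78900 nM. Compound 3 has the lowest number of the three, and its gap to compound 2 lies well beyond the usual scatter, so compound 3 is the strongest of the measured compounds.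

The next compound, compound 4 `COc1ccc(-c2oc3c(CC=C(C)C)c(OCC(=O)O)cc(O)c3c(=O)c2O)cc1`, differs from compound 3 in one place: hydrogen in place of ethyl on an oxygen next to a carbonyl group. Among the measured compounds shown here, no measured pair shows this exact step, so its size must be guessed from the wider picture. Compound 2, whose side chains are free acids, gives 78900 nM, far weaker than compound 3. Compound 1, also a free acid, sits at a limit of the assay. On that basis compound 4 is expected to be weaker than compound 3, with an upward step of a 5.7-fold higher number from compound 3 to compound 4 (0.75 log units; beyond the scatter), likely beyond the scatter. The estimate for compound 4 is 30000 nM, expected to fall between 8000 nM and 100000 nM.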

Compound 4, half-maximal inhibitory concentration: 13500 nM
Estimate against measurement, compound 4: 2.2-fold (0.35 log units) above; the range from low to high includes it.
By their numbers in this assay, from the lowest: compound 3; then compound 4; then compound 2. At a limit, above all of these: compound 1.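

In this assay, hydrogen in place of ethyl on an oxygen next to a carbonyl group, which turns the ethoxycarbonyl end of the side chain into a carboxy group, gives a 2.5-fold higher number from compound 3 to compound 4 (0.41 log units; beyond the scatter). The change is modest, so a compound with a free carboxymethyl chain can still give a measured number in this assay, and the ethyl ester is not needed for that. The other new comparison, hydrogen in place of carboxymethyl on an oxygen on an aromatic ring, gives an at least 7.4-fold lower number from compound 1 to compound 4 (0.86 log units; beyond the scatter), so carrying a second carboxymethyl chain goes with a weaker result, and because compound 1 gives a limit rather than a number, this step has only a minimum size: the limit of > 100000 nM in this assay, at which 1 of the 4 values shown sits.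

The compounds shown leave open how the number moves with other groups at the end of this chain, such as a methyl ester, a longer ester chain or a primary amide. They also leave open whether a small methyl group on the oxygen that carries hydrogen in compound 4 would behave more like that hydrogen or like carboxymethyl.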